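Cytotoxicity notes on the shared-core series, compound 2 to 3

A few compounds are considered here, and "the series" means these few. Any claim that something is new, unique, unknown or untested is made for them only; others in the source may bear on it.

Measured so far:
- compound 1, `CNc1ccc2nc(-c3c(Cl)nc(N)nc3N[C@@H]3C[C@H](CO)[C@@H](O)[C@H]3O)sc2c1`: 6000 nM
- compound 2, `Cc1nc(NCC(C)C)nc(N[C@@H]2C[C@H](CO)[C@@H](O)[C@H]2O)c1-c1nc2ccccc2s1`: 10000 nM

In an ADME assay on cells (Homo sapiens) for cytotoxicity, read by polymerase chain reaction, with a stated time of 3 days (a lower number here means that less compound is tolerated, a higher number that more compound is tolerated), compound 1 gives 6000 nM and compound 2 gives 10000 nM. The gap between the two lies within the scatter, so on the numbers shown compound 2 cannot be told apart from compound 1; no ordering is claimed.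

Compound 3, `Cc1nc(NCCNS(C)(=O)=O)nc(N[C@@H]2C[C@H](CO)[C@@H](O)[C@H]2O)c1-c1nc2ccccc2s1`, has not been measured in this assay. It differs from compound 2 in one place: (methanesulfonamido)methyl in place of isopropyl on a saturated chain carbon bound to a nitrogen on an aromatic ring. Within the data shown here, no measured pair in the set carries this change, so there is no direct precedent for its effect on tolerated concentration.

Given that both measured compounds sit close together, compound 3 is expected to stay near them, with the estimated step of no change at the digits printed from compound 2 to compound 3 (within the scatter) not beyond the scatter in either direction. The estimate for compound 3 in this assay is 10000 nM, with a range from 4000 nM to 25000 nM.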

Compound 3, half-maximal cytotoxic concentration: > 25000 nM
Compound 3: no number, only a limit (the forecaster's own chance of this, stated with the estimate: 30%); middle value at least 2.5-fold (0.39 log units) from the limit.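

Compound 3 gives only a limit, not a number: the limit of > 25000 nM in this assay, at which 1 of the 3 values shown sits.

Among these compounds, this position on a saturated chain carbon bound to a nitrogen on an aromatic ring does respond in this assay: (methanesulfonamido)methyl in place of isopropyl gives an at least 2.5-fold higher number from compound 2 to compound 3 (0.39 log units; beyond the scatter), the first step in the set that is read as beyond the scatter. Compound 1 and compound 2 differ in more than one place and gave no reading of this position, so this single pair is the only view of it, and it points towards more compound being tolerated.

As far as these compounds go, the true size of the step stays open, as one side of it is only a limit. From the compounds shown here alone, whether a plain longer chain, an amine or a carboxylic acid at this place would give a similar step also stays open, so the pair cannot say which part of the entering group goes with the change.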